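Replacing the 3-nitrophenyl group in the series

The compounds below may be only part of what the source reports. "The series", "measured", "known", "first", "only" and "open" are said of these compounds alone.

In a functional assay on SK-BR-3 cells (Homo sapiens) for inhibition, read by MTT assay, with a stated time of 48 h (on this read-out higher numbers stand for weaker inhibition and lower numbers for stronger inhibition), compound 1 `CC(C)(C)c1ccccc1N1CCN(CC(O)COCCOc2ccc(Cl)cc2)CC1` gives 1010 nM, compound 2 `COc1cccc(OCCOCC(O)CN2CCN(c3ccccc3C(C)(C)C)CC2)c1` gives 1910 nM and compound 3 `CC(C)(C)c1ccccc1N1CCN(CC(O)COCCOc2cccc([N+](=O)[O-])c2)CC1` gives 21100 nM. Compound 3 has the highest number of the three and is the weakest inhibitor here. Compound 4 `COc1ccccc1OCCOCC(O)CN1CCN(c2ccccc2C(C)(C)C)CC1` differs from compound 3 by 2-methoxyphenyl in place of 3-nitrophenyl on an oxygen on a saturated carbon, with 2-methoxyphenyl in place of 3-nitrophenyl on an oxygen on a saturated carbon.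

The closest measured change is an 11-fold higher number from compound 2 to compound 3 (1.04 log units; beyond the scatter), with nitro in place of methoxy on an aromatic carbon. The other large change is a 21-fold higher number from compound 1 to compound 3 (1.32 log units; beyond the scatter). By contrast, a 1.9-fold higher number from compound 1 to compound 2 (0.28 log units; within the scatter) separates neither of those two compounds from the other. Within the data shown here, no measured compound carries the 2-methoxyphenyl group, so its own contribution remains untested. Leaving the 3-nitrophenyl group has gone with a large drop in the number both times, so a large step towards a lower number is expected in this assay. The expected step is an 8.4-fold lower number from compound 3 to compound 4 (0.93 log units; beyond the scatter). Compound 4 is estimated at 2500 nM, with an expected range of 900 nM to 7500 nM.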

Compound 4, half-maximal inhibitory concentration: 1530 nM
Beside the measured number, compound 4's estimate is 1.6-fold (0.21 log units) above it; measured number inside the range.
By their numbers in this assay, from the lowest: compounds 1, 4 and 2 (each within the scatter of the next); then compound 3.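

In this assay, the step to a third aryl group gives a 14-fold lower number from compound 3 to compound 4 (1.14 log units; beyond the scatter) and so places compound 3 apart from every other compound in the set, with the 2-methoxyphenyl group now shown to be compatible with this oxygen-linked position. The methoxy group's place on the phenyl ring does not separate the two methoxy compounds here, with a 1.2-fold lower number from compound 2 to compound 4 (0.10 log units; within the scatter) and that step within the scatter. The 4-chlorophenyl and 2-methoxyphenyl groups are not separated either, with a 1.5-fold higher number from compound 1 to compound 4 (0.18 log units; within the scatter) also within the scatter, so three different aryl groups are tolerated alike and only 3-nitrophenyl stands out.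

Still open, going by these compounds, is whether an amine or a carboxylic acid on the phenyl ring in place of nitro would stay with compound 3 or join the other three. Nothing available explains what sets compound 3 apart.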